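A few compounds are considered here, and "the series" means these few. Any claim that something is new, unique, unknown or untested is made for them only; others in the source may bear on it.

In an assay on isolated protein for inhibition of histone deacetylase 8 (Homo sapiens), with a stated time of 1 h (a higher number here means a weaker inhibitor, a lower number a stronger inhibitor), compound 1 `COc1cccc(NC(=O)COc2ccc3cc(/C=C4/SC(=O)NC4=O)ccc3c2)c1` gives 7600 nM, and compound 2 `CCOc1ccc2nc(NC(=O)COc3ccc4cc(/C=C5/SC(=O)NC5=O)ccc4c3)sc2c1` gives 17000 nM. Compound 3 `Cc1cc(NC(=O)COc2ccc3cc(/C=C4/SC(=O)NC4=O)ccc3c2)no1` reaches only the limit of > 50000 nM in this assay, so its place is a bound rather than a number. The step of an at least 6.5-fold higher number from compound 1 to compound 3 (0.81 log units; beyond the scatter) is accordingly a floor on the loss, its size set by the limit of > 50000 nM in this assay, at which 1 of the 3 values shown sits. Compound 4 `O=C(COc1ccc2cc(/C=C3/SC(=O)NC3=O)ccc2c1)Nc1cccc(C(F)(F)F)c1` carries 3-(trifluoromethyl)phenyl in place of 5-methyl-1,2-oxazol-3-yl on an amide-type nitrogen. Only an at least 6.5-fold higher number from compound 1 to compound 3 (0.81 log units; beyond the scatter) bears on this change, and it runs the opposite way; the shared core and the amide linkage are unchanged. A return toward the level of compound 1 is expected, and the expected step is an at least 6.2-fold lower number from compound 3 to compound 4 (0.79 log units; beyond the scatter). Compound 4 is estimated at 8000 nM, within 2500 nM to 30000 nM, in this assay.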

Compound 4, half-maximal inhibitory concentration: > 50000 nM
Compound 4: a limit, no number; the forecaster's own chance of this, stated with the estimate: 15%; middle value at least 6.2-fold (0.79 log units) away from the limit.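

In this assay compound 4 gives > 50000 nM, which is a limit and not a number. Trifluoromethyl in place of methoxy on an aromatic carbon gives an at least 6.5-fold higher number from compound 1 to compound 4 (0.81 log units; beyond the scatter), so a loss of this kind is not confined to the 5-methyl-1,2-oxazol-3-yl group and also occurs with a phenyl ring on the amide-type nitrogen. The step between compound 3 and compound 4 cannot be read, and the comparison ends at the assay limit: the limit of > 50000 nM in this assay, at which 2 of the 4 values shown sit.

Going by these compounds, the true size of the loss in compound 4 remains open. Also open, on these data alone, is whether an amine or a carboxylic acid in place of methoxy on that aromatic carbon would retain the level of compound 1.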